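The source may hold more compounds than are shown below. What is called first, only, known or untested is meant among the compounds shown, and "the series" means these compounds.

Measured in a functional assay on HL-60 cells (Homo sapiens) for antiproliferative activity, read by MTT assay, with a stated time of 72 h; a lower number here means a stronger inhibitor, a higher number a weaker inhibitor:
compound 1 `NC1=NC2(CCSCC2)N(OCCCOc2ccc(Cl)c(Cl)c2)C(N)=N1`: 140 nM
compound 2 `NC1=NC2(CCOCC2)N(OCCCOc2ccccc2Cl)C(N)=N1`: 660 nM
compound 3 `NC1=NC2(CCOCC2)N(OCCCOc2ccc(F)cc2)C(N)=N1`: 2380 nM

Among these three, compound 1 has the lowest number, and its gaps to compound 2 and to compound 3 both lie beyond the usual scatter. Not yet measured is compound 4 `NC1=NC2(CCSCC2)N(OCCCOc2cccc(Cl)c2Cl)C(N)=N1`, which keeps the core of compound 1 and changes only the group on an oxygen on a saturated carbon: 2,3-dichlorophenyl in place of 3,4-dichlorophenyl on an oxygen on a saturated carbon. The two compounds have the same atoms, joined differently.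

Among the compounds with values here, only one measured step touches the group at this place. That step, a 3.6-fold higher number from compound 2 to compound 3 (0.56 log units; beyond the scatter), is modest but beyond the scatter. It shows that this assay can respond to a change here, but it was taken on a different core and exchanges one group for a quite different one. Within the data shown here, no measured pair shows what 2,3-dichlorophenyl does in place of 3,4-dichlorophenyl, so the evidence is thin. A step no larger than that modest one is expected, possibly none beyond the scatter. With compound 1 at 140 nM as the lowest of the set, a small rise seems likelier than a fall. The expected change is a 1.4-fold higher number from compound 1 to compound 4 (0.15 log units; within the scatter) in this reading. For compound 4 the estimated value is 200 nM, with an expected range from 70 nM to 550 nM.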

Compound 4, half-maximal inhibitory concentration: 30 nM
The estimate for compound 4 lay 6.7-fold (0.82 log units) above the measured number; the measured number lies below the stated range.
By their numbers in this assay, from the lowest: compound 4; then compound 1; then compound 2; then compound 3.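

In this assay, the exchange of 3,4-dichlorophenyl for 2,3-dichlorophenyl gives a 4.7-fold lower number from compound 1 to compound 4 (0.67 log units; beyond the scatter), a step beyond the usual scatter. Within the data shown here, the only earlier step at this place, a 3.6-fold higher number from compound 2 to compound 3 (0.56 log units; beyond the scatter), was taken on a different core and swapped one group for a quite different one, whereas this step stays on the core of compound 1 and compares two groups with the same count of heavy atoms, the same single aromatic ring and no hydrogen-bond donors or acceptors. It therefore shows that, on this core, the number responds to how the two chlorines are arranged on the phenyl ring and not only to which atoms the group contains, and that this rearrangement can lower the number, although nothing here shows why this exchange has that effect.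

The compounds shown leave open whether the same exchange would have a similar effect on the core shared by compound 2 and compound 3. They also leave open how this place would respond to 2,3-difluorophenyl or 2,3-dimethylphenyl, or to a group bearing an amine or a carboxylic acid.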